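A few compounds are considered here, and "the series" means these few. Any claim that something is new, unique, unknown or untested is made for them only; others in the source may bear on it.

Measured compounds in a functional assay on SW-620 cells (Homo sapiens) for antiproliferative activity, read by MTT assay, with a stated time of 72 h; on this read-out lower numbers stand for stronger inhibition and higher numbers for weaker inhibition:
- compound 1 `O=C1O/C(=C\Cn2cc(-c3ccc(Br)cc3)nn2)C(OCc2ccccc2)=C1OCc1ccccc1` gives > 100000 nM, a limit of the assay rather than a number.
- compound 2 `COc1ccccc1-c1cn(C[C@H](O)[C@H]2OC(=O)C(OCc3ccccc3)=C2OCc2ccccc2)nn1` gives > 100000 nM, likewise a limit of the assay.
- compound 3 `CCCCCc1ccc(-c2cn(C/C=C3\OC(=O)C(OCc4ccccc4)=C3OCc3ccccc3)nn2)cc1` gives > 100000 nM, again a limit of the assay.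

Compound 2 therefore stands only at a limit in this assay, and so do the two other compounds shown: the limit of > 100000 nM in this assay, at which 3 of the 3 values shown sit. Among the measured compounds shown here, the one measured step, a step that the two limits leave unreadable from compound 1 to compound 3, cannot be sized, since both ends are limits, and it concerns a different place on the shared core than the change now in view.

The change from compound 2 to compound 4 `O=C1O[C@H]([C@@H](O)Cn2ccnn2)C(OCc2ccccc2)=C1OCc1ccccc1` is hydrogen in place of 2-methoxyphenyl on an aromatic carbon. No measured step covers this change, so nothing shown gives a direction or a size for it. What is known is that compound 2 sits at the limit and that the step from compound 2 to compound 4 is expected to be a step that the limit leaves unreadable from compound 2 to compound 4, meaning no readable step. The most likely outcome for compound 4 is expected to be another limit in this assay because the limit of > 100000 nM in this assay, at which 3 of the 3 values shown sit, holds for every compound shown.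

Compound 4 is therefore estimated at 200000 nM in this assay, within 40000 nM to 1000000 nM.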

Compound 4, half-maximal inhibitory concentration: > 100000 nM
Compound 4: no number, only a limit (the forecaster's own chance of this, stated with the estimate: 80%); the middle value lies beyond the limit too.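

Compound 2 and compound 4 both stand at a limit rather than a number, so the step between them cannot be read. The compounds shown leave open which change to the shared core, if any, would give a readable number, since all stop at one value: the limit of > 100000 nM in this assay, at which 4 of the 4 values shown sit.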